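The compounds below may be only part of what the source reports. "The series", "measured", "known", "first", "only" and "open" are said of these compounds alone.

Compound 3 `C/C(=N/NC(=S)Nc1cccc(I)c1)c1ccccn1` carries an iodo group, and in a functional assay on MCF7 cells (Homo sapiens) for cytotoxicity, read by MTT assay, with a stated time of 48 h (on this read-out higher numbers stand for weaker inhibition and lower numbers for stronger inhibition), compound 3 gives 45 nM. Compound 1 `C/C(=N/NC(=S)Nc1cccc([N+](=O)[O-])c1)c1ccccn1` carries a nitro group in its place, and in this assay compound 1 gives 38 nM. That change, nitro in place of iodo on an aromatic carbon, made a 1.2-fold lower number from compound 3 to compound 1 (0.07 log units; within the scatter). Compound 2 `C/C(=N/NC(=S)Nc1ccccc1I)c1ccccn1` has the same atoms as compound 3 joined differently; how the two cores differ is not broken down here. In this assay compound 2 gives 4.1 nM, the lowest of the three numbers, beyond the scatter from both others. Compound 4 `C/C(=N/NC(=S)Nc1ccccc1[N+](=O)[O-])c1ccccn1` arises from compound 2 by the same kind of change, nitro in place of iodo on an aromatic carbon, here at a place ortho to a large group rather than meta to a large group. Because the earlier step of a 1.2-fold lower number from compound 3 to compound 1 (0.07 log units; within the scatter) stayed within the scatter, the expected step here is also small, a 1.7-fold higher number from compound 2 to compound 4 (0.23 log units; within the scatter). Compound 4 is therefore estimated at 7 nM, between 2 nM and 35 nM.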

Compound 4, half-maximal inhibitory concentration: 5.7 nM
The estimate for compound 4 lay 1.2-fold (0.09 log units) above the measured number, within the range that was stated.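

In this assay nitro in place of iodo gave a 1.4-fold higher number from compound 2 to compound 4 (0.14 log units; within the scatter) on this core, a small step like the earlier one. Set side by side, the two steps do not differ: the same change on two cores in this assay, a 1.2-fold lower number (0.07 log units; within the scatter) from compound 3 to compound 1 and a 1.4-fold higher number (0.14 log units; within the scatter) from compound 2 to compound 4, 1.6-fold (0.22 log units) apart, within the scatter of two such steps. For these two pairs, then, the change carried from one core to the other with little effect on the number, but two pairs cannot show why this is so, nor that it would hold on any further core.

The compounds shown leave open how an amine, a carboxylic acid or a methoxy group would behave at the place ortho to a large group. They also leave open whether a longer chain there would keep the number this low.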